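Cytotoxicity limits in a small ester series

The source may hold more compounds than are shown below. What is called first, only, known or untested is meant among the compounds shown, and "the series" means these compounds.

Measured so far:
Compound 1 `CCOC(=O)c1c(-c2cccc(Oc3ccccc3)c2)[nH]c2cc(OC)c(OC)cc2c1=O`: > 21500 nM
Compound 2 `CCOC(=O)c1c(-c2cccc(Oc3ccccc3)c2)[nH]c2cc(Cl)c(Cl)cc2c1=O`: > 21500 nM

Both entries are limits and not numbers. In an ADME assay on HepG2 cells (Homo sapiens) for cytotoxicity, read by luminescence, with a stated time of 72 h (on this read-out higher numbers stand for an effect only at larger amounts of compound and lower numbers for an effect already at smaller amounts), compound 2 gives only a limit, > 21500 nM. Compound 1 likewise gives only a limit, > 21500 nM. Neither compound can therefore be ranked against the other.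

Compound 3 `CCOC(=O)c1c(-c2cccc(Oc3ccccc3)c2)[nH]c2cc(OC)c(Cl)cc2c1=O` carries methoxy in place of chloro on an aromatic carbon of the shared core (methoxy in place of chloro on an aromatic carbon). The new methoxy stands ortho to a chloro group. No step beyond the usual scatter is expected in this assay, and no direction can be assigned. This expectation rests on (the limit of > 21500 nM in this assay, at which 2 of the 2 values shown sit). Another limit is the likely report for compound 3. The estimated change is small, a step that the limit leaves unreadable from compound 2 to compound 3. For compound 3 the expected value is 25000 nM, with an estimated range of 12000 nM to 50000 nM.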

Compound 3, half-maximal effective concentration: > 21500 nM
Compound 3 was reported as a limit; the forecaster's own chance of this, stated with the estimate: 85%; the middle value lies beyond the limit too.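

Compound 3 also gives only a limit, > 21500 nM. No step can be read among compound 1, compound 2 and compound 3, since all three entries sit at the same limit: the limit of > 21500 nM in this assay, at which 3 of the 3 values shown sit. Going by these compounds, what stays open is whether methoxy in place of chloro on the shared core alters cytotoxicity at all, and in which direction.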